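Paw edema series: removing the aminomethyl-piperidine from compound 2

This account rests on a few compounds, and the source may have more. Where it says the series, first, only, none or still open, it means among the compounds named here.

Measured in a functional assay on the whole organism (strain albino) for inhibition, with Rattus norvegicus as the target, read by paw edema, with stated times of 1 h and 3 h, at a dose of 20 mmol/kg by the intraperitoneal route; a lower number here means a weaker effect, a higher number a stronger effect of the compound at the dose given:
compound 1 `N#CC1=C(NCN2CCCC2)N(c2ccccc2)C(=O)N2CCCCC(N3CCCC3)C12`: 35.3%
compound 2 `N#CC1=C(NCN2CCCCC2)N(c2ccccc2)C(=O)N2CCCCC(N3CCCC3)C12`: 42.1%
compound 3 `N#Cc1c2n(c(=O)n(-c3ccccc3)c1=N)CCCCC2N1CCCC1`: 93.4%

Compound 2 stands second highest of the three numbers in this assay. Its nearest neighbour is compound 1, which sits lower, though the step of a number 6.8 percentage points higher from compound 1 to compound 2 (within the scatter) is within the scatter; the furthest is compound 3, which sits far higher, beyond the scatter. Among the measured compounds shown here, the only single-place step measured so far, from pyrrolidin-1-yl to piperidin-1-yl, thus changes nothing that can be read with confidence.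

Compound 4 `N#CC1=C(N)N(c2ccccc2)C(=O)N2CCCCC(N3CCCC3)C12` is not yet measured. It differs from compound 2 by hydrogen in place of (piperidin-1-yl)methyl on an amine nitrogen. For the measured compounds named here, no measured step concerns this amine nitrogen, so nothing in the measured steps bears directly on the change. The values of compound 1 and compound 2 set the level of the two compounds that carry a substituted amine; compound 3, with a different core, gives the high number in this assay. Taking the two groups of numbers together, compound 4 is expected to lie between them, with wide uncertainty, so a step of a number 22.9 percentage points higher from compound 2 to compound 4 (beyond the scatter) is estimated. The expected value for compound 4 in this assay is 65%, with a range from 35% to 95%.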

Compound 4, a percentage reported as inhibition, in the whole organism at one dose (the size of the read-out at that dose, not a potency): 90.1%
Estimate against measurement, compound 4: 25.1 percentage points below; measured number inside the range.
By their numbers in this assay, from the lowest: compounds 1 and 2 (each within the scatter of the next); then compounds 4 and 3 (each within the scatter of the next).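

In this assay the amine nitrogen on the double-bonded ring carbon turns out to be a place where the read-out responds strongly: hydrogen in place of (piperidin-1-yl)methyl gives a number 48 percentage points higher from compound 2 to compound 4 (beyond the scatter), and hydrogen in place of (pyrrolidin-1-yl)methyl gives a number 54.8 percentage points higher from compound 1 to compound 4 (beyond the scatter). The earlier exchange of pyrrolidin-1-yl for piperidin-1-yl on the chain carbon stayed within the scatter, whereas removing the whole substituent gives a large step in the same direction from either starting compound, so that compound 4 , with its plain amino group, reaches 90.1% at the dose given. Nothing measured here accounts for this gain, and no explanation of it can be offered from the data at hand.

Going by these compounds, whether the gain depends on the unsubstituted amino group, or whether a methyl or an acetyl group on this nitrogen would keep it, remains open. Also open, on these data alone, is how far the pyrrolidin-1-yl group on the saturated ring carbon contributes in compound 4 , for instance against a morpholin-4-yl group or a plain hydrogen there.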